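A few compounds are considered here, and "the series" means these few. Any claim that something is new, unique, unknown or untested is made for them only; others in the source may bear on it.

- compound 1 `Oc1ccc2ccccc2c1C(Nc1nc2ccccc2s1)c1cn(-c2ccccc2)nc1-c1ccccc1` gives 48900 nM
- compound 2 `COc1cccc(-c2nn(-c3ccccc3)cc2C(Nc2nc3ccc(OC)cc3s2)c2c(O)ccc3ccccc23)c1` gives 62600 nM

Both numbers come from a functional assay on MCF7 cells (Homo sapiens) for antiproliferative activity, read by MTT assay, with a stated time of 48 h (a lower number here means a stronger inhibitor, a higher number a weaker inhibitor), and they stand close together. Compound 2 at 62600 nM lies within the usual scatter of compound 1 at 48900 nM so the two cannot be ranked.

Compound 3 `COc1ccc2nc(NC(c3cn(-c4ccccc4)nc3-c3ccccc3)c3c(O)ccc4ccccc34)sc2c1` has not yet been measured. It is compound 2 with one change hydrogen in place of methoxy on an aromatic carbon in which hydrogen takes the place of methoxy on an aromatic carbon, so that 3-methoxyphenyl becomes phenyl.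

Within the data shown here, no two measured compounds differ in one place only, so this change has no direct precedent here. Among the measured compounds shown here, the only guide is the narrow gap between the two measured values, which gives no reason to expect a shift in either direction beyond the scatter in this assay for this change. The estimated change is a 1.1-fold lower number from compound 2 to compound 3 (0.06 log units; within the scatter) and so it is expected to stay within the scatter. For compound 3 the estimated value is 55000 nM with an expected range from 25000 nM to 110000 nM once it is measured.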

Compound 3, half-maximal inhibitory concentration: 40800 nM
Compound 3: middle estimate off by 1.3-fold (0.13 log units), on the high side; measured number inside the range.
By their numbers in this assay, from the lowest: compounds 3, 1 and 2 (each within the scatter of the next).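

Among these compounds, two single changes can now be read for the first time, both measured in one test (this assay). Hydrogen in place of methoxy on an aromatic carbon, meta to a large group, turns 3-methoxyphenyl into phenyl and gives a step (a 1.5-fold lower number from compound 2 to compound 3 (0.19 log units; within the scatter)) that stays within the scatter, so methoxy and hydrogen cannot be told apart at this position. Methoxy in place of hydrogen on an aromatic carbon, at a different place in the molecule, gives a step (a 1.2-fold lower number from compound 1 to compound 3 (0.08 log units; within the scatter)) that also stays within the scatter, and no measurement here offers an explanation for either result.

The compounds shown compare only methoxy and hydrogen at each of these two places, leaving open whether an amine, a carboxylic acid or a longer chain such as butoxy would move the number beyond the scatter. They also leave open whether either step would stay this small on a compound that differs elsewhere in the shared core.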